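Alkyl Ester Series: Cytotoxicity Limit and the Pentyl Analogue

The source may report more compounds than this note shows. Statements on the series, on what has been measured and on what is new or still open speak of the compounds shown alone.

The series shares one core carrying a hydroxy ester; only the ester side group varies. Compound 1 `COCCOC(=O)C(O)Cn1cnc2c(N)ncnc21`, compound 2 `CC(C)(C)OC(=O)C(O)Cn1cnc2c(N)ncnc21` and compound 3 `CCCOC(=O)C(O)Cn1cnc2c(N)ncnc21` have been tested in a functional assay on Vero cells (Chlorocebus sabaeus) for cytotoxicity; on this read-out higher numbers stand for lower toxicity in this test and lower numbers for higher toxicity in this test. In this assay compound 1 reaches only the assay limit > 400 ug/mL. In this assay compound 2 likewise stops at the limit > 400 ug/mL. In this assay compound 3 also returns only the limit > 400 ug/mL. Accordingly a step that the two limits leave unreadable from compound 1 to compound 2, a step that the two limits leave unreadable from compound 1 to compound 3 and a step that the two limits leave unreadable from compound 2 to compound 3, as shown by the limit of > 400 ug/mL in this assay, at which 3 of the 3 values shown sit. Compound 3 thus stands at the same limit as the other two, with no number to place it.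

Compound 4 `CCCCCOC(=O)C(O)Cn1cnc2c(N)ncnc21` has not been measured. It differs from compound 3 by ethyl in place of hydrogen on a saturated chain carbon, three bonds along the chain from an oxygen next to a carbonyl group. Among the measured compounds shown here, none of the measured steps has a readable size, so no direction can be drawn from them; the step of a number no higher from compound 3 to compound 4 (the limit leaves the size open) is an expectation only. Compound 4 is expected to give 400 ug/mL in this assay, within 150 ug/mL to 1000 ug/mL, most likely again reported as a limit.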

Compound 4, minimum cytotoxic concentration: 200 ug/mL
For compound 4 the middle estimate is 2.0-fold (0.30 log units) above the measured one; measured number inside the range.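

In this assay, among the compounds shown here, the pentyl ester is the first member of the series to give a number rather than a limit, and ethyl in place of hydrogen on a saturated chain carbon, three bonds along the chain from an oxygen next to a carbonyl group, gives an at least 2.0-fold lower number from compound 3 to compound 4 (0.30 log units; that floor lies within the scatter) and so a first, still tentative, sign of a drop at this position. The other two comparisons read the same way, with pentyl in place of tert-butyl giving an at least 2.0-fold lower number from compound 2 to compound 4 (0.30 log units; that floor lies within the scatter) and propyl in place of methoxy giving an at least 2.0-fold lower number from compound 1 to compound 4 (0.30 log units; that floor lies within the scatter) as floors only. Going by these compounds, the steps among compounds 1, 2 and 3 cannot be read, and the true size of each new step stays open: the limit of > 400 ug/mL in this assay, at which 3 of the 4 values shown sit.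

On these data alone, whether a longer chain such as hexyl or octyl gives a lower number than compound 4 remains open. So does the reading for a benzyl ester or a branched pentyl ester.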